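This account rests on a few compounds, and the source may have more. Where it says the series, first, only, none or still open, it means among the compounds named here.

Measured so far:
compound 1 `COc1ccc(F)cc1-c1cccc(-c2n[nH]c(=O)o2)c1` — 41%
compound 2 `COc1ccc(F)cc1-c1cccc(-c2nn(CCCCF)c(=O)o2)c1` — 51%

For the measured compounds named here, in a functional assay on the whole organism (strain Wistar albino) for inhibition, with Rattus norvegicus as the target, read by paw edema, with stated times of 30 min and 1 h, at a dose of 10 mg/kg by the oral route (a lower number here means less inhibition, a higher number more inhibition at the dose given (going by the name of the read-out)), compound 2 stands at 51%; its only neighbour is compound 1 at 41%, and the two lie within the scatter of each other. Going by the values given here, the single measured step, a number 10 percentage points higher from compound 1 to compound 2 (within the scatter), is within the scatter.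

Compound 3 `COc1ccc(F)cc1-c1cccc(-c2nn(CCOC3CCCCO3)c(=O)o2)c1` differs from compound 2 by (oxan-2-yl)oxy in place of 2-fluoroethyl on a saturated chain carbon, two bonds along the chain from an aromatic nitrogen. Among the compounds with values here, no measured step touches this place on the chain; the one step known, a number 10 percentage points higher from compound 1 to compound 2 (within the scatter), alters the group on the aromatic nitrogen without moving the number beyond the scatter. No step beyond the scatter is therefore expected, so the estimated step is a number 1 percentage points lower from compound 2 to compound 3 (within the scatter). Compound 3 is expected at 50%, range 35% to 65%.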

Compound 3, a percentage reported as inhibition, in the whole organism at one dose (the size of the read-out at that dose, not a potency): 32%
For compound 3 the middle estimate is 18 percentage points above the measured one; measured number outside the range, below it.
By their numbers in this assay, from the lowest: compounds 3, 1 and 2 (each within the scatter of the next, the first and the last beyond it).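

In this assay, for the compounds shown here, the group at this place on the chain is not free to vary: (oxan-2-yl)oxy in place of 2-fluoroethyl gives a number 19 percentage points lower from compound 2 to compound 3 (beyond the scatter) and is the first change to reach beyond the scatter. Set against hydrogen on the aromatic nitrogen, the whole 2-((oxan-2-yl)oxy)ethyl group gives only a number 9 percentage points lower from compound 1 to compound 3 (within the scatter) as its step. Nothing on hand bears on the reason for either step. Left open is whether a 2-hydroxyethyl chain or an amine at the chain end would read like compound 2 or like compound 3.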